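Moving the ring substituent: from 2-ethylphenyl to 3-bromophenyl

This account rests on a few compounds, and the source may have more. Where it says the series, first, only, none or still open, it means among the compounds named here.

Of the compounds shown here, three that share one core have been measured in an assay on microsomes from liver for inhibition of acyl-CoA desaturase 1 (Rattus norvegicus); a lower number here means a stronger inhibitor, a higher number a weaker inhibitor. Compound 1 `Cc1ccc(OC2CCN(c3ccc(-n4ccnc4)nn3)CC2)cc1` gives 527 nM in this assay, compound 2 `Cc1cccc(OC2CCN(c3ccc(-n4ccnc4)nn3)CC2)c1` gives 251 nM, and compound 3 `CCc1ccccc1OC1CCN(c2ccc(-n3ccnc3)nn2)CC1` gives 4 nM. Compound 3 stands lowest of the three; the step of a 63-fold lower number from compound 2 to compound 3 (1.80 log units; beyond the scatter) and the step of a 130-fold lower number from compound 1 to compound 3 (2.12 log units; beyond the scatter) are both large and well beyond the scatter, whereas the step of a 2.1-fold lower number from compound 1 to compound 2 (0.32 log units; beyond the scatter) is modest.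

Compound 4 `Brc1cccc(OC2CCN(c3ccc(-n4ccnc4)nn3)CC2)c1` differs from compound 3 by one change: 3-bromophenyl in place of 2-ethylphenyl on an oxygen on a saturated carbon. The measured step that bears most directly on this change is a 63-fold lower number from compound 2 to compound 3 (1.80 log units; beyond the scatter), since it also exchanges a 3-substituted phenyl for the 2-ethylphenyl. Reversing that direction, a large rise in the number is expected from compound 3 to compound 4, roughly of the size seen between compound 2 and compound 3, with the understanding that no measured compound carries a bromine. For compound 4 the estimated step is a 38-fold higher number from compound 3 to compound 4 (1.57 log units; beyond the scatter), and compound 4 is expected to give about 150 nM in this assay, within a range from 30 nM to 800 nM.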

Compound 4, half-maximal inhibitory concentration: 23 nM
Compound 4: middle estimate off by 6.5-fold (0.81 log units), on the high side, and the stated range ends above it.
By their numbers in this assay, from the lowest: compound 3; then compound 4; then compound 2; then compound 1.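

In this assay, the change of bromo in place of methyl on an aromatic carbon alone gives an 11-fold lower number from compound 2 to compound 4 (1.04 log units; beyond the scatter) and so shows that the substituent, and not only where it sits, matters on this phenyl ring. A 3-substituted phenyl is therefore not tied to a weak number, since 3-bromophenyl in place of 4-methylphenyl gives a 23-fold lower number from compound 1 to compound 4 (1.36 log units; beyond the scatter) in the same assay. The 2-ethylphenyl group keeps the lowest number, but the step to 3-bromophenyl is only modest, with a 5.8-fold higher number from compound 3 to compound 4 (0.76 log units; beyond the scatter) as its size.

No evidence at hand explains these differences. The compounds shown leave open whether chloro or methoxy in place of bromo would give a similar number, and how a 2-bromophenyl would compare with the 2-ethylphenyl.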